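This account rests on a few compounds, and the source may have more. Where it says the series, first, only, none or still open, it means among the compounds named here.

Values in a functional assay on A549 cells (Homo sapiens) for antiproliferative activity, read by MTT assay, with a stated time of 48 h; a higher number here means a weaker inhibitor, a lower number a stronger inhibitor:
- compound 1 `COc1cc(/C=N/c2c(C#N)ncn2-c2ccc(F)cc2)ccc1O`: 13600 nM
- compound 2 `N#Cc1ncn(-c2ccc(F)cc2)c1/N=C/c1ccc(O)cc1`: 16300 nM
- compound 3 `CC(C)c1ccc(/C=N/c2c(C#N)ncn2-c2ccc(F)cc2)cc1`: not yet measured

Within the data shown here, compound 2 lies within the scatter of compound 1, the only other measured compound. Compound 3 carries isopropyl in place of hydroxy on an aromatic carbon, para to a large group: isopropyl in place of hydroxy on an aromatic carbon. Among the measured compounds shown here, the one measured step, a 1.2-fold higher number from compound 1 to compound 2 (0.08 log units; within the scatter), is hydrogen in place of methoxy and lies within the scatter. It leaves the hydroxy untouched, so it bears only loosely on this change. In this assay, no shift beyond the scatter is expected, in either direction. The expected step is a 1.3-fold lower number from compound 2 to compound 3 (0.10 log units; within the scatter). For compound 3 the estimated value is 13000 nM, with an expected range of 4500 nM to 38000 nM.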

Compound 3, half-maximal inhibitory concentration: 14700 nM
Compound 3: middle estimate off by 1.1-fold (0.05 log units), on the low side; low and high end bracket the measured number.
By their numbers in this assay, from the lowest: compounds 1, 3 and 2 (each within the scatter of the next).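

In this assay, among these compounds, the step from hydroxy to isopropyl (a 1.1-fold lower number from compound 2 to compound 3 (0.04 log units; within the scatter)) is the first change at this place, on an aromatic carbon para to a large group, and it shows no shift beyond the scatter. Here the hydroxy, with its hydrogen-bond donor and acceptor, can give way to a group of three carbon atoms with neither donor nor acceptor, and the number stays within the scatter. No supporting evidence bears on this result. On these data alone, whether an amine or a carboxylic acid at this place would behave the same stays open. So does whether isopropyl would do so with the methoxy of compound 1 present.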